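The compounds below may be only part of what the source reports. "The series", "measured", "known", "first", "only" and "open" are said of these compounds alone.

Series values in a functional assay on Hep cells (Homo sapiens) for cytotoxicity, read by sulforhodamine B assay, with a stated time of 48 h; on this read-out lower numbers stand for stronger inhibition and higher numbers for weaker inhibition:

- compound 1 `C=CCOc1cc(Br)ccc1C(=O)c1cccnc1`: > 100000 nM (a limit of the assay, not a number)
- compound 2 `O=C(c1cccnc1)c1ccccc1O`: 31000 nM

Going by the values given here, compound 2 holds the only actual number so far, at 31000 nM. With just one number and one limit in hand, there is no ranking to speak of, and compound 2 is the sole numerical reference point.

The next compound, compound 3 `O=C(c1cccnc1)c1ccc(Br)cc1O`, differs from compound 2 in one place: bromo in place of hydrogen on an aromatic carbon, meta to a hydroxy group and para to a group of 8 heavy atoms (bromo in place of hydrogen on an aromatic carbon). Compound 1 also carries a bromo group, but it differs from compound 3 in more than that one place. The value of compound 1, > 100000 nM, is a limit. Among the compounds with values here, no measured pair isolates this change, so the expectation in this assay starts from compound 2 at 31000 nM. No shift beyond the usual scatter is expected in either direction, with only a slight lean towards stronger inhibition. The estimated change is a 1.2-fold lower number from compound 2 to compound 3 (0.09 log units; within the scatter). For compound 3 the expected value is 25000 nM, within an estimated range of 9000 nM to 80000 nM.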

Compound 3, half-maximal inhibitory concentration: 85000 nM
Beside the measured number, compound 3's estimate is 3.4-fold (0.53 log units) below it; the measured number lies above the stated range.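

In this assay, going by these compounds alone, the first one-place comparison of the series puts bromo in place of hydrogen on an aromatic carbon, meta to a hydroxy group and para to a group of 8 heavy atoms, and it reads a 2.7-fold higher number from compound 2 to compound 3 (0.44 log units; beyond the scatter); at this position, with the hydroxy group kept, bromo goes with weaker inhibition, a modest move that is beyond the scatter. The second step, hydrogen in place of allyl on the oxygen, reads an at least 1.1-fold lower number from compound 1 to compound 3 (0.07 log units; that floor lies within the scatter) and so gives no order between the two compounds, leaving the allyl group's contribution unresolved. Compound 1 holds a limit and not a number: the limit of > 100000 nM in this assay, at which 1 of the 3 values shown sits.

One bromo compound cannot tell whether this step belongs to bromo itself or to any substituent at this position, and a chloro, a methyl or an amino group in the same place would separate those readings. Going by these compounds, the effect of a shorter group on the oxygen, such as methyl, also stays open, as does that of allyl on the oxygen without the bromo group.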